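Swapping chloro for fluoro on a trimethoxy chalcone scaffold

This account rests on a few compounds, and the source may have more. Where it says the series, first, only, none or still open, it means among the compounds named here.

Three compounds built on the shared core have been examined in a functional assay on MDA-MB-231 cells (Homo sapiens), read by fluorescence and BrdU incorporation, with a stated time of 48 h, tested at 25 uM; on this read-out lower numbers stand for a stronger effect and higher numbers for a weaker effect at the one concentration tested. Compound 1 `COc1cc(O)c(C(=O)/C=C/c2ccc(F)cc2)c(OC)c1` was recorded as "not active" (no number reported), with no number reported. Compound 2 `COc1cccc(/C=C/C(=O)c2c(OC)cc(OC)cc2OC)c1` gives 12% in this assay, and compound 3 `COc1cc(OC)c(C(=O)/C=C/c2ccc(Cl)cc2)c(OC)c1` gives 2.1%. For the measured compounds named here, compound 3 thus sits at the low end of the two numbers available, yet the one step that separates it from the nearest compound, a number 9.9 percentage points lower from compound 2 to compound 3 (within the scatter), lies within the scatter, so the two cannot be told apart with confidence.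

Compound 4 `COc1cc(OC)c(C(=O)/C=C/c2ccc(F)cc2)c(OC)c1` has not yet been measured. It differs from compound 3 in a single place: fluoro in place of chloro on an aromatic carbon. Going by the values given here, no measured pair shows this same exchange, so no step bears on it directly. Compound 1 also carries a 4-fluorophenyl group but differs from compound 4 in a second place; the record of compound 1, "not active" (no number reported), is not a number, and it can only be noted, not weighed as a step. Among the compounds with values here, with no guiding step and a small change, compound 4 is expected to give about 10% in this assay, between 1% and 40%, a step of a number 7.9 percentage points higher from compound 3 to compound 4 (within the scatter) that is estimated to stay within the scatter.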

Compound 4, a percentage reported as activity, at one concentration (the size of the read-out at that concentration, not a potency): 10%
Compound 4: the middle estimate sits on the measured number at the digits printed, and the stated range covers the measured number.
By their numbers in this assay, from the lowest: compounds 3, 4 and 2 (each within the scatter of the next).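

In this assay the exchange of chloro for fluoro on an aromatic carbon, para to a large group, now has a reading of its own, a number 7.9 percentage points higher from compound 3 to compound 4 (within the scatter), so at this place the two substituents cannot be told apart on this read-out. The 4-fluorophenyl group also cannot be separated from the 3-methoxyphenyl group, with a number 2 percentage points lower from compound 2 to compound 4 (within the scatter), and the three numbers now available form a set in which each lies within the scatter of the next, so none of these changes at this end of the chalcone has yet been seen to move the read-out with confidence. Nothing measured here explains why these compounds read alike, and no supporting data on that question are available.

For the compounds shown here, compound 1, which carries the same 4-fluorophenyl group on a differently substituted core, is recorded as "not active" (no number reported) and gives no step that can be read, so the contribution of that other place remains unsettled. On these data alone, whether an amine or a carboxylic acid on this same aromatic carbon would carry the number beyond the scatter also stays open.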